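From a Dimethylphenyl to a Fluorophenyl Amine

A few compounds are considered here, and "the series" means these few. Any claim that something is new, unique, unknown or untested is made for them only; others in the source may bear on it.

Of the compounds shown here, three built on one shared core have been tested in a functional assay on MGC-803 cells (Homo sapiens) for inhibition, read by sulforhodamine B assay; a lower number here means a stronger inhibitor, a higher number a weaker inhibitor. Compound 1 `Cc1ccc(NC2=CC(=O)c3nc4n(c3C2=O)[C@H]2OC[C@@H](O)[C@H]2OC4)cc1C` gives 860 nM in this assay, the lower of the two plain numbers available. Compound 3 `O=C1C(Nc2ccc(Br)cc2)=CC(=O)c2c1nc1n2[C@H]2OC[C@@H](O)[C@H]2OC1`, which carries a (4-bromophenyl)amino group in the same place, gives 2020 nM in this assay, a higher number that lies beyond the usual scatter. Compound 2 `O=C1C(N2CCCCC2)=CC(=O)c2c1nc1n2[C@H]2OC[C@@H](O)[C@H]2OC1`, with piperidin-1-yl instead of an arylamine, reaches only > 4000 nM in this assay, which is a limit of the assay rather than a number. The step of an at least 1.9-fold lower number from compound 2 to compound 3 (0.29 log units; that floor lies within the scatter) therefore rests on (the limit of > 4000 nM in this assay, at which 1 of the 3 values shown sits), and its true size is not known.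

Compound 4 `O=C1C=C(Nc2cccc(F)c2)C(=O)c2c1nc1n2[C@H]2OC[C@@H](O)[C@H]2OC1` differs from compound 1 by 3-fluorophenyl in place of 3,4-dimethylphenyl on an amine nitrogen. Both compounds keep an arylamino group, so the nearest guide is compound 3, whose 4-bromophenyl variant gives a higher number than the 3,4-dimethylphenyl of compound 1. A smaller halogen-bearing ring is expected to fall between those two. Compound 4 is therefore estimated to give about 1500 nM in this assay, within a range from 600 nM to 4000 nM. That expectation corresponds to a step of a 1.7-fold higher number from compound 1 to compound 4 (0.24 log units; within the scatter), a modest weakening.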

Compound 4, half-maximal inhibitory concentration: 2180 nM
Beside the measured number, compound 4's estimate is 1.5-fold (0.16 log units) below it; the measured number falls inside the stated range.
By their numbers in this assay, from the lowest: compound 1; then compounds 3 and 4 (each within the scatter of the next). At a limit, above all of these: compound 2.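

Among these compounds, replacing 3,4-dimethylphenyl with 3-fluorophenyl on the amine nitrogen gives a 2.5-fold higher number from compound 1 to compound 4 (0.40 log units; beyond the scatter) in this assay and is the first readable step between two arylamines that both have plain numbers, showing that this position responds to a change of the ring alone. Compound 3 at 2020 nM and compound 4 at 2180 nM lie within the scatter of each other, so two different halogen-bearing rings now share one range, and both numbers are higher than that of compound 1 at 860 nM in these few compounds. Nothing measured here explains the step.

This change removes two methyl groups and adds a fluorine in one move, so the compounds shown leave open which of these accounts for the step; a plain phenyl ring or a 4-methylphenyl ring on the same amine nitrogen would help to separate them. Also open, on these data alone, is whether the amine nitrogen itself needs an aryl ring at all, which a benzyl group or a morpholine at this place would begin to test.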